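The source may report more compounds than this note shows. Statements on the series, on what has been measured and on what is new or still open speak of the compounds shown alone.

Measured so far in a functional assay on DU-145 cells (Homo sapiens) for inhibition, read by trypan blue exclusion, with a stated time of 96 h; on this read-out higher numbers stand for weaker inhibition of growth and lower numbers for stronger inhibition of growth:
- compound 1 `COc1ccccc1/C=C(/SCc1ccc(F)cc1)C(=O)c1ccc(Br)cc1` gives 10000 nM
- compound 2 `CN(C)c1ccc(/C=C(/SCc2ccc(F)cc2)C(=O)c2ccc(Br)cc2)cc1` gives 50000 nM
- compound 3 `CN(C)c1ccc(/C=C(/SCc2ccc(F)cc2)C(=O)c2ccc(C(=O)O)cc2)cc1` gives 10000 nM

Compound 2 stands highest of the three at 50000 nM on these numbers, so it inhibits growth the least. Compound 4 `O=C(/C(=C\c1ccc2ccccc2n1)SCc1ccc(F)cc1)c1ccc(Br)cc1` carries quinolin-2-yl in place of 4-(dimethylamino)phenyl on a double-bonded chain carbon bound to a double-bonded chain carbon and is otherwise the same.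

The most relevant measured step is at this same place: a 5.0-fold higher number from compound 1 to compound 2 (0.70 log units; beyond the scatter). Read backwards, it shows that replacing 4-(dimethylamino)phenyl there can bring the number down. The other step, a 5.0-fold lower number from compound 2 to compound 3 (0.70 log units; beyond the scatter), is carboxy in place of bromo on an aromatic carbon, a change compound 4 does not make, so it bears little on this question. Among the measured compounds shown here, no measured compound carries quinolin-2-yl, so the direction is only tentative.

A modest fall is expected, with the estimated change being a 3.3-fold lower number from compound 2 to compound 4 (0.52 log units; beyond the scatter). In this assay the estimate for compound 4 is 15000 nM with an expected range from 4000 nM to 60000 nM.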

Compound 4, concentration for 50% growth inhibition: 25000 nM
The estimate for compound 4 lay 1.7-fold (0.22 log units) below the measured number; the range from low to high includes it.
By their numbers in this assay, from the lowest: compounds 1 and 3 (each within the scatter of the next); then compounds 4 and 2 (each within the scatter of the next).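

In this assay, quinolin-2-yl in place of 4-(dimethylamino)phenyl on a double-bonded chain carbon bound to a double-bonded chain carbon gives a 2.0-fold lower number from compound 2 to compound 4 (0.30 log units; within the scatter), so this change does not separate the two groups. The earlier step showed that the number at this place can move, but a larger group with a second ring does not clearly move it; set against the 2-methoxyphenyl group, quinolin-2-yl gives a 2.5-fold higher number from compound 1 to compound 4 (0.40 log units; beyond the scatter), so with bromo kept, only 2-methoxyphenyl stands apart from the other two groups. Nothing available explains this order.

Going by these compounds, what remains open is whether the methoxy group itself matters or whether other groups at this place would match it. A plain phenyl and a pyridin-2-yl would test this, and carboxy in place of bromo on compound 4 remains an open case too.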